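A few compounds are considered here, and "the series" means these few. Any claim that something is new, unique, unknown or untested is made for them only; others in the source may bear on it.

Measured compounds:
Compound 1 `COc1cc2nc(N3CCN(S(=O)(=O)c4ccc(I)cc4)CC3)nc(N)c2cc1OC`: in a functional assay on PC-3 cells (Homo sapiens) for inhibition (on this read-out higher numbers stand for weaker inhibition and lower numbers for stronger inhibition), compound 1 gives 15000 nM.
Compound 2 `COc1cc2nc(N3CCN(S(=O)(=O)c4ccc(C)cc4)CC3)nc(N)c2cc1OC`: in this assay compound 2 gives 30000 nM.
Compound 3 `COc1cc2nc(N3CCN(S(=O)(=O)c4ccc(S(C)(=O)=O)cc4)CC3)nc(N)c2cc1OC`: in this assay compound 3 gives 17000 nM.

Compound 3 stands second highest of the three numbers, but the spread is small: the step of a 1.1-fold higher number from compound 1 to compound 3 (0.05 log units; within the scatter) and the step of a 1.8-fold lower number from compound 2 to compound 3 (0.25 log units; within the scatter) both lie within the scatter, as does a 2.0-fold higher number from compound 1 to compound 2 (0.30 log units; within the scatter). Three different groups on the same aromatic carbon thus give numbers that cannot be told apart.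

Compound 4 `COc1cc2nc(N3CCN(S(=O)(=O)c4ccc(-c5ccc(C)cc5)cc4)CC3)nc(N)c2cc1OC` carries the change (4-methylphenyl in place of methylsulfonyl on an aromatic carbon), placed on an aromatic carbon of a six-membered aromatic ring of carbon only, para to a large group. Among the measured compounds shown here, no measured step brings in a second aromatic ring at this place, so the only bearing steps are those among compounds 1, 2 and 3, each within the scatter. On that record no step beyond the scatter is expected in this assay for compound 4, with the new ring an open question. The estimate for compound 4 is 13000 nM, with a range of 4000 nM to 40000 nM, meaning an expected step of a 1.3-fold lower number from compound 3 to compound 4 (0.12 log units; within the scatter).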

Compound 4, half-maximal inhibitory concentration: 3400 nM
For compound 4 the middle estimate is 3.8-fold (0.58 log units) above the measured one, and the stated range ends above it.
By their numbers in this assay, from the lowest: compound 4; then compounds 1, 3 and 2 (each within the scatter of the next).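

In this assay this position had shown no step beyond the scatter, and 4-methylphenyl is the first group on this aromatic carbon to shift the number clearly, with the three steps reading (a 5.0-fold lower number from compound 3 to compound 4 (0.70 log units; beyond the scatter)), (an 8.8-fold lower number from compound 2 to compound 4 (0.95 log units; beyond the scatter)) and (a 4.4-fold lower number from compound 1 to compound 4 (0.64 log units; beyond the scatter)). The position is therefore not indifferent to what it carries: compound 4 gives stronger inhibition than the methylsulfonyl, methyl and iodo compounds, all of which remain within the scatter of one another. The information at hand offers no explanation for this step.

As far as these compounds go, it remains open whether the second aromatic ring alone accounts for the step or whether its methyl group also contributes, as an unsubstituted phenyl would show. From the compounds shown here alone, it is equally open whether a pyridine ring, an amine or a longer alkyl chain at this place would give a similar number.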